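A Methyl Added to the Chain of Compound 3

This account rests on a few compounds, and the source may have more. Where it says the series, first, only, none or still open, it means among the compounds named here.

Of the compounds shown here, three have been measured in an assay on microsomes from intestine for inhibition of acyl-CoA:cholesterol acyltransferase (Oryctolagus cuniculus) (on this read-out lower numbers stand for stronger inhibition and higher numbers for weaker inhibition), and a fourth awaits measurement. Compound 1 `CCCCCCCC/C=C/CCCCCCCC(=O)Nc1c(C)cccc1OC` gives 20 nM in this assay. Compound 2 `CCCCCCCC/C=C/CCCCCCCC(=O)Nc1c(C)cccc1OCC` differs from it by methyl in place of hydrogen on a saturated chain carbon bound to an oxygen on an aromatic ring, and in this assay compound 2 gives 15 nM; the step is a 1.3-fold lower number from compound 1 to compound 2 (0.12 log units; within the scatter). Compound 3 `CCCCCCCCCCCCCCCC(=O)Nc1c(OC)cc(OC)cc1OC` carries another core, and how its core differs from that of compound 1 is not broken down here. In this assay compound 3 gives 54 nM, the highest number of the three. Compound 4 `CCCCCCCCCCCCCCC(C)C(=O)Nc1c(OC)cc(OC)cc1OC` is not yet measured; it differs from compound 3 by methyl in place of hydrogen on a saturated chain carbon bound to a carbonyl carbon and a saturated chain carbon. This is the same kind of change as that from compound 1 to compound 2, a methyl in place of hydrogen, but the place differs: there the carbon is bound to an oxygen on an aromatic ring, here to a carbonyl carbon and a saturated chain carbon. For compound 4 the expected step is a 1.2-fold lower number from compound 3 to compound 4 (0.08 log units; within the scatter). Within the data shown here, that expectation rests on the one measured step of this kind, a 1.3-fold lower number from compound 1 to compound 2 (0.12 log units; within the scatter), which stayed within the scatter. In this assay compound 4 is estimated at 45 nM, with a range from 18 nM to 120 nM.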

Compound 4, half-maximal inhibitory concentration: 31 nM
The estimate for compound 4 lay 1.5-fold (0.16 log units) above the measured number, within the range that was stated.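

In this assay, methyl in place of hydrogen on the chain carbon bound to the carbonyl carbon gives a 1.7-fold lower number from compound 3 to compound 4 (0.24 log units; within the scatter), and set beside the earlier step on the other core, the two agree: the same change on two cores in this assay, a 1.3-fold lower number (0.12 log units; within the scatter) from compound 1 to compound 2 and a 1.7-fold lower number (0.24 log units; within the scatter) from compound 3 to compound 4, 1.3-fold (0.12 log units) apart, within the scatter of two such steps. Since both steps and the gap between them lie within the scatter, the change carried from one core to the other in these two pairs without a step that can be told from repeated measurement. This does not show that the methyl strengthens inhibition on either core, and two pairs that place the methyl on different carbons give no rule for other cores.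

The compounds shown leave open whether a larger or different group on the carbon bound to the carbonyl carbon, such as a phenyl or a hydroxyl group, would give a step beyond the scatter. They also leave open whether a second methyl on that same carbon would do so.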